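The source may report more compounds than this note shows. Statements on the series, on what has been measured and on what is new or still open speak of the compounds shown alone.

Values measured so far in a functional assay on A549 cells (Homo sapiens) for cytotoxicity, read by MTT assay, with a stated time of 72 h; a lower number here means a stronger inhibitor, a higher number a weaker inhibitor

Compound 1 `COC(=O)c1sc2c(C)cccc2c1Nc1cc(OC)c(OC)c(OC)c1` gives 3930 nM
Compound 2 `COC(=O)c1sc2nc(C)ccc2c1Nc1cc(OC)c(OC)c(OC)c1` gives 16.2 nM
Compound 3 `COC(=O)c1sc2ncccc2c1Nc1cc(OC)c(OC)c(OC)c1` gives 3850 nM

In this assay compound 3 cannot be told apart from compound 1, and both stand far from compound 2. Compound 4 `CCOC(=O)c1sc2ncccc2c1Nc1cc(OC)c(OC)c(OC)c1` differs from compound 3 only in carrying ethoxycarbonyl where compound 3 has methoxycarbonyl (methyl in place of hydrogen on a saturated chain carbon bound to an oxygen next to a carbonyl group). This places methyl in place of hydrogen on a saturated chain carbon bound to an oxygen next to a carbonyl group.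

Among the measured compounds shown here, only one measured step bears on this change, and only indirectly. It is a 240-fold higher number from compound 2 to compound 3 (2.38 log units; beyond the scatter) and it is large, with hydrogen in place of methyl on an aromatic carbon. That pair shows that a single methyl can matter a great deal on this core, but its methyl sits at a different place from the new one. For the measured compounds named here, no measured pair alters the methoxycarbonyl group, so the data give no firm direction, and the range has to stay wide on both sides. The expected change is a 1.0-fold higher number from compound 3 to compound 4 (0.02 log units; within the scatter) and no shift beyond the scatter is expected. For compound 4 the estimate is 4000 nM with an expected range of 1000 nM to 15000 nM.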

Compound 4, half-maximal inhibitory concentration: 7160 nM
Estimate against measurement, compound 4: 1.8-fold (0.25 log units) below; the range from low to high includes it.
By their numbers in this assay, from the lowest: compound 2; then compounds 3, 1 and 4 (each within the scatter of the next).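

In this assay, the change from methoxycarbonyl to ethoxycarbonyl gives a 1.9-fold higher number from compound 3 to compound 4 (0.27 log units; within the scatter), so compound 3 and compound 4 cannot be told apart in this test. Among the compounds shown here, this is the first direct look at this group, and it shows that the shared core tolerates methyl in place of hydrogen on this saturated chain carbon without a shift beyond the usual scatter. The contrast with a 240-fold higher number from compound 2 to compound 3 (2.38 log units; beyond the scatter), where the methyl sits on an aromatic carbon, shows that among these pairs the effect of a methyl depends on where it stands, though nothing available here explains the result or the contrast.

Methoxycarbonyl and ethoxycarbonyl are a small step, so it remains open whether a longer chain such as butoxycarbonyl, or a carboxylic acid or an amide in the same place, would keep the number or move it. On these data alone, it is also open whether ethoxycarbonyl would be tolerated as well alongside the aromatic methyl of compound 2, which gives 16.2 nM.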